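Fluoro in Place of Dimethylamino on Compound 1

The compounds below may be only part of what the source reports. "The series", "measured", "known", "first", "only" and "open" are said of these compounds alone.

Compound 1 `Cc1ccc2nc(-c3ccccc3N(C)C)[nH]c(=O)c2c1` gives 82.9% in an assay on isolated protein for inhibition of DNA topoisomerase 1 (Homo sapiens), with a stated time of 30 min, tested at 100 uM; on this read-out lower numbers stand for a weaker effect and higher numbers for a stronger effect at the one concentration tested. Compound 2 `CCN(CC)c1ccc2nc(-c3ccccc3N(C)C)[nH]c(=O)c2c1` gives 82.1%, and the step of a number 0.8 percentage points lower from compound 1 to compound 2 (within the scatter) lies within the scatter, so the two stand together on this read-out. The unmeasured compound 3 `Cc1ccc2nc(-c3ccccc3F)[nH]c(=O)c2c1` differs from compound 1 by fluoro in place of dimethylamino on an aromatic carbon. Among the compounds with values here, no measured step changes the dimethylamino group, so the only step at hand, a number 0.8 percentage points lower from compound 1 to compound 2 (within the scatter), touches a different place and bears on the new change only in showing that the read-out tolerated one substituent swap on an aromatic carbon. Without a step at the dimethylamino itself, the size expected for compound 3 is uncertain. Compound 3 is expected to give 68%, within 45% to 88%. The estimated step of a number 14.9 percentage points lower from compound 1 to compound 3 (beyond the scatter) is judged likely to fall beyond the scatter, toward weaker inhibition, but a value near that of compound 1 cannot be ruled out.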

Compound 3, a percentage reported as inhibition, at one concentration (the size of the read-out at that concentration, not a potency): 67.9%
For compound 3 the middle estimate is 0.1 percentage points above the measured one; the range from low to high includes it.
By their numbers in this assay, from the lowest: compound 3; then compounds 2 and 1 (each within the scatter of the next).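

In this assay the swap of dimethylamino for fluoro gives a number 15 percentage points lower from compound 1 to compound 3 (beyond the scatter) and so makes this place, on an aromatic carbon ortho to a large group, the one place among those shown where a change moves the number beyond the scatter. The step is modest, and compound 3 still gives 67.9% at the one concentration tested, so the dimethylamino group is not needed for a sizeable read-out. Nothing at hand accounts for the step.

As far as these compounds go, whether the lower number follows from losing dimethylamino or from gaining fluoro stays open, and a hydrogen, a methoxy or a chloro at this place would be needed to separate the two. Also open, from the compounds shown here alone, is whether fluoro here has the same effect when diethylamino replaces the methyl group.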